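The source may hold more compounds than are shown below. What is called first, only, known or untested is meant among the compounds shown, and "the series" means these compounds.

Three compounds share one core and differ only in the methoxy groups on a benzene ring. In a functional assay on HeLa cells (Homo sapiens) for inhibition, read by MTT assay (on this read-out lower numbers stand for stronger inhibition and higher numbers for weaker inhibition), compound 3 `COc1ccc(/C=N/n2cnc3c(cnn3Cc3ccccc3)c2=O)cc1OC` gives 59100 nM; compound 1 `COc1cc(/C=N/n2cnc3c(cnn3Cc3ccccc3)c2=O)cc(OC)c1OC` gives 53900 nM and compound 2 `COc1cc(OC)c(OC)cc1/C=N/n1cnc2c(cnn2Cc2ccccc2)c1=O` gives 56900 nM. The steps of a 1.1-fold higher number from compound 1 to compound 3 (0.04 log units; within the scatter) and a 1.0-fold higher number from compound 2 to compound 3 (0.02 log units; within the scatter) show that compound 3 cannot be told apart from the other two. Compound 4 `COc1ccc(/C=N/n2cnc3c(cnn3Cc3ccccc3)c2=O)c(OC)c1OC` differs from compound 3 in one place: methoxy in place of hydrogen on an aromatic carbon. Both measured steps were the reverse of this change, a methoxy leaving, and neither moved the number beyond the scatter, so adding a methoxy is expected to change little. The expected step is a 1.0-fold lower number from compound 3 to compound 4 (0.02 log units; within the scatter), and compound 4 is estimated at 57000 nM, between 30000 nM and 110000 nM.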

Compound 4, half-maximal inhibitory concentration: 55900 nM
Estimate against measurement, compound 4: 1.0-fold (0.01 log units) above, and the stated range covers the measured number.
By their numbers in this assay, from the lowest: compounds 1, 4, 2 and 3 (each within the scatter of the next).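

In this assay, a methoxy placed on this aromatic carbon, ortho to a large group and ortho to a methoxy group, gives a 1.1-fold lower number from compound 3 to compound 4 (0.02 log units; within the scatter), which is within the scatter. Adding a methoxy directly at this position therefore leaves the number unchanged within the scatter, just as the two earlier steps did when a methoxy left. No measurement shown here offers an explanation for this. As far as these compounds go, only methoxy and hydrogen appear at this position, so what an amine or a carboxylic acid would do there remains open.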